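Notes on an aryl swap at the aromatic nitrogen

The compounds below may be only part of what the source reports. "The series", "measured", "known", "first", "only" and "open" are said of these compounds alone.

Three compounds of the series have been run in a functional assay on HepG2 cells (Homo sapiens) for antiproliferative activity, read by MTT assay, with a stated time of 48 h; on this read-out higher numbers stand for weaker inhibition and lower numbers for stronger inhibition. Compound 1 `N#CC1=C(N)Oc2c(c3nc4ccccc4nc3c3ccccc23)C12C(=O)N(Cc1cnnn1-c1ccccc1Br)c1ccccc12` returns only a limit of the assay in this assay, > 50000 nM. Compound 2 `Cc1ccc(-n2nncc2CN2C(=O)C3(C(C#N)=C(N)Oc4c3c3nc5ccccc5nc3c3ccccc43)c3ccccc32)cc1Cl` likewise returns a limit in this assay, > 50000 nM. The step that the two limits leave unreadable from compound 1 to compound 2 is therefore unreadable because of the limit of > 50000 nM in this assay, at which 2 of the 3 values shown sit. Within the data shown here, compound 3 `N#CC1=C(N)Oc2c(N)cc3nc4ccccc4nc3c2C12C(=O)N(Cc1cnnn1-c1ccccc1Cl)c1ccccc12` is the single member with a number in this assay, 33500 nM, and stands alone on that account; no order among the three can be stated from these figures.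

Compound 4 `N#CC1=C(N)Oc2c(N)cc3nc4ccccc4nc3c2C12C(=O)N(Cc1cnnn1-c1ccc([N+](=O)[O-])cc1)c1ccccc12` differs from compound 3 in one place: 4-nitrophenyl in place of 2-chlorophenyl on an aromatic nitrogen. Among the measured compounds shown here, no measured step speaks to this exchange with a readable size, since the only comparison at an aromatic nitrogen, a step that the two limits leave unreadable from compound 1 to compound 2, is lost between two limits. With nothing pointing to a shift beyond the usual scatter, the expected step is a 1.0-fold higher number from compound 3 to compound 4 (0.02 log units; within the scatter), taken as flat. In this assay compound 4 is accordingly estimated at 35000 nM, with a range from 12000 nM to 60000 nM. Given that two of the three measured values in this assay are limits, compound 4 may well return a limit rather than a number.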

Compound 4, half-maximal inhibitory concentration: > 50000 nM
Compound 4 gave a limit, no number; the forecaster's own chance of this, stated with the estimate: 40%; at least 1.4-fold (0.15 log units) between middle value and limit.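

Among these compounds, at the aromatic nitrogen of the five-membered ring, the exchange of 2-chlorophenyl for 4-nitrophenyl gives the first step at this position with a readable direction in this assay, an at least 1.4-fold higher number from compound 3 to compound 4 (0.17 log units; that floor lies within the scatter). On these data alone, that figure is only a floor set by the limit of compound 4, so the true size of the step stays unknown, and the floor alone establishes no shift beyond the scatter, though 4-nitrophenyl brings no lower number than 2-chlorophenyl on this core. The series now sits almost wholly at a limit, with compound 3 the only member that carries a number: the limit of > 50000 nM in this assay, at which 3 of the 4 values shown sit.

The exchange alters both the substituent and its place on the phenyl ring, so the pair cannot say which of the two matters; a 4-chlorophenyl or a 2-nitrophenyl on the same nitrogen would separate them. Also open, as far as these compounds go, is whether any group here can bring the number clearly below that of compound 3, for instance an unsubstituted phenyl, a phenyl bearing an amine or a carboxylic acid, or a plain alkyl chain in place of the aryl ring.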